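The source may report more compounds than this note shows. Statements on the series, on what has been measured and on what is new or still open speak of the compounds shown alone.

Working notes on the series. Of the compounds shown here, two have numbers so far: compound 1 `Cc1ccc(-c2ccncc2F)c(C(=O)N2CCC(O)(Cc3ccccc3)CC2)c1` and compound 2 `Cc1ccc(C(=O)N2CCC(O)(Cc3ccccc3)CC2)c(-c2ccncc2)c1`. In an assay for inhibition of cholesterol 24-hydroxylase (Homo sapiens), using NADPH, with stated times of 15 min and 5 min (on this read-out higher numbers stand for weaker inhibition and lower numbers for stronger inhibition), compound 1 gives 17 nM. Within the data shown here, in the same read-out compound 2 gives 4.4 nM, the lowest number of the pair, and the gap between the two values lies beyond the usual scatter; compound 1 and compound 2 differ in more than one place, so no single step is drawn from one to the other.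

The next compound to be measured is compound 3 `O=C(c1ccccc1-c1ccncc1)N1CCC(O)(Cc2ccccc2)CC1`. Compared with compound 2 the change is hydrogen in place of methyl on an aromatic carbon. Among the measured compounds shown here, no step of this exact kind between measured compounds exists, so no measured precedent sets its size. Loss of a single methyl on the core is expected to cost a small amount of potency, the step of a 2.0-fold higher number from compound 2 to compound 3 (0.31 log units; beyond the scatter) being estimated as a slight rise in number, close to the scatter. For compound 3 the value in this assay is expected near 9 nM, with a range from 3 nM to 30 nM.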

Compound 3, half-maximal inhibitory concentration: 7.9 nM
Estimate against measurement, compound 3: 1.1-fold (0.06 log units) above, within the range that was stated.
By their numbers in this assay, from the lowest: compounds 2 and 3 (each within the scatter of the next); then compound 1.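

On the aromatic carbon meta to the pyridin-4-yl group and para to a large group, hydrogen in place of methyl gives a 1.8-fold higher number from compound 2 to compound 3 (0.25 log units; within the scatter) and so sets compound 2 and compound 3 level in this assay as far as this read-out can tell. Among these compounds, this is the first single-place comparison, and it shows that the methyl at this position is not required for a low number when the rest of the structure stays the same. Nothing at hand gives a reason for this result.

Only methyl and hydrogen are shown on this carbon, so the outcome with a chlorine atom, a methoxy group, an amine or a carboxylic acid there remains open. The fluorine of compound 1 also remains unresolved, since compound 1 differs from compound 2 and from compound 3 in more than one place.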